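Cyclopropyl for Isopropyl on the Pyranose Side Chain

The source may hold more compounds than are shown below. What is called first, only, known or untested is meant among the compounds shown, and "the series" means these compounds.

Three C-glycosidic analogues of a shared core carry the same three benzyl ether groups and differ in the substituent on a saturated chain carbon bound to a saturated ring carbon. In a functional assay on HL-60 cells (Homo sapiens) for antiproliferative activity, read by MTT assay (a lower number here means a stronger inhibitor, a higher number a weaker inhibitor), compound 1 `O[C@@H]1[C@@H](OCc2ccccc2)[C@H](OCc2ccccc2)[C@@H](COCc2ccccc2)O[C@H]1CC1CCCCC1` gives 4100 nM, while compound 2 `O[C@H]1CO[C@H](COCc2ccccc2)[C@@H](OCc2ccccc2)[C@@H]1OCc1ccccc1` gives "not active" (no number reported) with no number reported. Compound 3 `CC(C)C[C@@H]1O[C@H](COCc2ccccc2)[C@@H](OCc2ccccc2)[C@H](OCc2ccccc2)[C@H]1O` gives 8500 nM in this assay, the highest of the two numbers at hand, and the step of a 2.1-fold higher number from compound 1 to compound 3 (0.32 log units; beyond the scatter) places it beyond the scatter from compound 1.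

Compound 4 `O[C@@H]1[C@@H](OCc2ccccc2)[C@H](OCc2ccccc2)[C@@H](COCc2ccccc2)O[C@H]1CC1CC1` is not yet measured. It differs from compound 3 in one place: cyclopropyl in place of isopropyl on a saturated chain carbon bound to a saturated ring carbon. Within the data shown here, the only step that bears on this change is the one from compound 1 to compound 3, where a ring gave way to an open chain and the number rose modestly. For compound 4 the return of a ring, now three-membered, is expected to move the number in the opposite direction by a step no larger than the scatter itself, with an expected step of a 1.4-fold lower number from compound 3 to compound 4 (0.15 log units; within the scatter). Compound 4 is therefore estimated at 6000 nM in this assay, within a range of 2500 nM to 15000 nM.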

Compound 4, half-maximal inhibitory concentration: "not active" (no number reported)
No number was reported for compound 4; no gap can be computed for the estimate.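

Among these compounds, compound 4 was reported in this assay without a number, so no step from compound 3 to compound 4 can be read. The compounds shown leave open how far cyclopropyl and isopropyl differ at this place. No supporting data explain the result.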